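A few compounds are considered here, and "the series" means these few. Any claim that something is new, unique, unknown or untested is made for them only; others in the source may bear on it.

Of the compounds shown here, three built on a shared core have been measured in a functional assay on HCT-116 cells (Homo sapiens) for inhibition, read by sulforhodamine B assay, with a stated time of 72 h; a lower number here means a stronger inhibitor, a higher number a weaker inhibitor. Compound 1 `COc1ccc(C2=Nn3c(nnc3C(C)c3ccc4cc(OC)ccc4c3)SC2)cc1` gives 6500 nM, compound 3 `COc1ccc(C2=Nn3c(nnc3C(C)c3ccc(-c4ccccc4)c(F)c3)SC2)cc1` gives 4400 nM, and compound 2 `CC(C)Cc1ccc(C(C)c2nnc3n2N=C(c2ccc(Br)cc2)CS3)cc1` gives 7100 nM. The number for compound 2 is the largest of the three, but its distance to compound 1 and its distance to compound 3 both fall within the usual scatter of repeated measurements, so these numbers do not separate the three compounds by potency.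

Compound 4 `CC(C)Cc1ccc(C(C)c2nnc3n2N=C(c2ccccc2)CS3)cc1` is the next compound to be measured in this assay. It differs from compound 2 in one place: hydrogen in place of bromo on an aromatic carbon. Cut one bond further out, the change reads 4-bromophenyl to phenyl.

For the measured compounds named here, no step between two measured compounds is available in this set, so nothing here shows how such a change has played out before. One heavy atom leaves and a hydrogen enters, and the expectation is a step from compound 2 to compound 4 that stays within the scatter, with no clear direction, estimated as a 1.1-fold higher number from compound 2 to compound 4 (0.05 log units; within the scatter). Compound 4 is therefore expected to give about 8000 nM, with a likely range from 3500 nM to 18000 nM.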

Compound 4, half-maximal inhibitory concentration: 7600 nM
Estimate against measurement, compound 4: 1.1-fold (0.02 log units) above; low and high end bracket the measured number.
By their numbers in this assay, from the lowest: compounds 3, 1, 2 and 4 (each within the scatter of the next).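

In this assay, for the compounds shown here, the change from 4-bromophenyl to phenyl gives a 1.1-fold higher number from compound 2 to compound 4 (0.03 log units; within the scatter) and is the first step in this set between two compounds that differ in one place. On this aromatic carbon, para to a large group, the bromo can therefore give way to hydrogen without the number moving beyond the scatter, so within this pair the one heavy atom that leaves makes no measurable difference to the read-out. The set offers no measurement that could account for this result, and a single step cannot say why the position responds as it does.

What the compounds shown leave open is whether this position responds to anything at all, since bromo and hydrogen are the only two groups compared there on otherwise identical compounds, and an amine, a carboxylic acid or a longer chain at the same carbon could behave quite differently. Going by these compounds, it also remains open whether the same change would read the same way on the cores of compound 1 and compound 3, which differ from compound 2 in more than one place.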